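This account rests on a few compounds, and the source may have more. Where it says the series, first, only, none or still open, it means among the compounds named here.

The measured compounds:

Compound 1, `COc1ncnc2c1c(-c1ccoc1)cn2[C@@H]1O[C@H](CO)[C@@H](O)[C@H]1O`: in a functional assay on HepG2 cells (Homo sapiens) for antiproliferative activity, read by XTT assay, with a stated time of 72 h (on this read-out lower numbers stand for stronger inhibition and higher numbers for weaker inhibition), compound 1 gives 290 nM.
Compound 2, `CNc1ncnc2c1c(-c1ccoc1)cn2[C@@H]1O[C@H](CO)[C@@H](O)[C@H]1O`: in this assay compound 2 reaches only the limit of the assay, > 20000 nM.
Compound 3, `COc1ncnc2c1c(-c1cc3ccccc3o1)cn2[C@@H]1O[C@H](CO)[C@@H](O)[C@H]1O`: in this assay compound 3 also reaches only the limit of the assay, > 20000 nM.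

Compound 1 is the only one of the three with a numerical value. Compound 2 differs from it in one place: methylamino in place of methoxy on an aromatic carbon. This change made a large step, an at least 68-fold higher number from compound 1 to compound 2 (1.83 log units; beyond the scatter). Compound 3 differs from compound 1 in its core: 1-benzofuran-2-yl in place of furan-3-yl on an aromatic carbon. That change too produced a large step, an at least 68-fold higher number from compound 1 to compound 3 (1.83 log units; beyond the scatter). Because (the limit of > 20000 nM in this assay, at which 2 of the 3 values shown sit), the true size of either step is not known; each is only a lower bound.

Compound 4, `CNc1ncnc2c1c(-c1cc3ccccc3o1)cn2[C@@H]1O[C@H](CO)[C@@H](O)[C@H]1O`, is not yet measured. It stands to compound 3 as compound 2 stands to compound 1: methylamino in place of methoxy on an aromatic carbon. The place is described in the same words for both pairs, so it is the same change. Here, though, it starts from a compound that already sits at the limit. For compound 4 the step is expected to be a step that the limit leaves unreadable from compound 3 to compound 4. That expectation rests on compound 3, which reaches only the limit > 20000 nM of the assay. It also rests on the step of an at least 68-fold higher number from compound 1 to compound 2 (1.83 log units; beyond the scatter), which went upward when the same change was made alone. Compound 4 is estimated at 40000 nM, between 15000 nM and 200000 nM, and will most likely be reported only as a limit.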

Compound 4, half-maximal inhibitory concentration: > 20000 nM
Compound 4: a limit, no number; the forecaster's own chance of this, stated with the estimate: 90%; the middle value is on the limit's open side.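

Compound 4 cannot be compared with compound 3 or with compound 2, so no new step can be read, because each of these compounds sits at the same limit of the assay rather than giving a number: the limit of > 20000 nM in this assay, at which 3 of the 4 values shown sit.

The compounds shown leave open the true values of compound 2, compound 3 and compound 4, and so whether methylamino in place of methoxy changes anything when 1-benzofuran-2-yl is present.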